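Truncating the acyl chain across two anilide series

The source may report more compounds than this note shows. Statements on the series, on what has been measured and on what is new or still open speak of the compounds shown alone.

Compound 1 `CCCCCCCCC(=O)N1c2ccccc2CCC1C(=O)Nc1ccccc1C(F)(F)F` carries a long acyl chain and, in a functional assay on PC-3 cells (Homo sapiens) for cytotoxicity, read by sulforhodamine B assay, with a stated time of 72 h (on this read-out higher numbers stand for weaker inhibition of growth and lower numbers for stronger inhibition of growth), compound 1 gives 4320 nM. Compound 2 `CCC(=O)N1c2ccccc2CCC1C(=O)Nc1ccccc1C(F)(F)F` differs from it by hydrogen in place of hexyl on a saturated chain carbon, two bonds along the chain from a carbonyl carbon. In this assay compound 2 reaches only the limit of the measurement, > 80000 nM. The resulting step is an at least 18-fold higher number from compound 1 to compound 2 (1.26 log units; beyond the scatter), and the evidence for its size rests on (the limit of > 80000 nM in this assay, at which 1 of the 3 values shown sits). Compound 3 `CCCCCCCCC(=O)N1c2ccccc2CCC1C(=O)Nc1cc(C(F)(F)F)cc(C(F)(F)F)c1` keeps the long chain but bears a different anilide; the difference between the core of compound 3 and the core of compound 1 is not broken down here. In this assay compound 3 gives 7430 nM, a value that sits within the scatter of compound 1. Among the measured compounds shown here, compound 4 `CCC(=O)N1c2ccccc2CCC1C(=O)Nc1cc(C(F)(F)F)cc(C(F)(F)F)c1` is not yet measured and differs from compound 3 by hydrogen in place of hexyl on a saturated chain carbon, two bonds along the chain from a carbonyl carbon, the same change as the one from compound 1 to compound 2. On that basis the step from compound 3 to compound 4 is expected to be a 13-fold higher number from compound 3 to compound 4 (1.13 log units; beyond the scatter), by analogy with an at least 18-fold higher number from compound 1 to compound 2 (1.26 log units; beyond the scatter). Compound 4 is therefore estimated at 100000 nM, with a range from 40000 nM to 300000 nM.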

Compound 4, concentration for 50% growth inhibition: 8540 nM
Compound 4: the middle estimate sits 12-fold (1.07 log units) above what was measured; the whole stated range lies above it.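

In this assay the same shortening of the chain gives a 1.1-fold higher number from compound 3 to compound 4 (0.06 log units; within the scatter), so the large step seen on the core of compound 1 does not carry over to the core of compound 3: the same change on two cores in this assay, an at least 18-fold higher number (1.26 log units; beyond the scatter) from compound 1 to compound 2 and a 1.1-fold higher number (0.06 log units; within the scatter) from compound 3 to compound 4, at least 16-fold (1.20 log units) apart, beyond the scatter of two such steps. Compound 2 gives > 80000 nM, which is a limit of the assay and not a number, so the size of the earlier step is known from one side only: the limit of > 80000 nM in this assay, at which 1 of the 4 values shown sits. The two pairs show that the result of this change depends on the core it is made on, but they do not show which part of the anilide sets the difference, or how the change would behave on any third core.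

Still open, from the compounds shown here alone, is how a butanoyl or hexanoyl chain would behave on each of the two cores. Also open, going by these compounds, is whether an anilide bearing a nitrile or a carboxylic acid in place of trifluoromethyl would follow the pair of compound 1 and compound 2 or the pair of compound 3 and compound 4.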